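Furan to Thiazole on the Amide Nitrogen Side Chain

This account rests on a few compounds, and the source may have more. Where it says the series, first, only, none or still open, it means among the compounds named here.

Of the compounds shown here, three sharing one core have been measured in an assay on HEK293 cells for agonist activity at transient receptor potential cation channel subfamily M member 8 (Homo sapiens), read by fluorescence and calcium flux, with a stated time of 15 min; on this read-out higher numbers stand for an effect only at larger amounts of compound and lower numbers for an effect already at smaller amounts. Compound 1 `CCN(Cc1cccs1)C(=O)COc1ccc(F)cc1` gives 422 nM. Compound 2 `Cc1ccc(OCC(=O)N(Cc2cccs2)CC(C)C)cc1` gives 900 nM. Compound 3 `CCN(Cc1ccoc1)C(=O)COc1ccc(C)cc1` gives 136 nM, the lowest number of the three; its gaps to compound 1 and to compound 2 both lie beyond the usual scatter of repeated measurements. No two of these compounds differ in a single place, so no single step can be read from them.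

Compound 4 `CCN(Cc1cncs1)C(=O)COc1ccc(C)cc1` differs from compound 3 in one place: 1,3-thiazol-5-yl in place of furan-3-yl on a saturated chain carbon bound to an amide-type nitrogen. Within the data shown here, nothing among the measured compounds isolates this exchange, and the three numbers available give only a loose frame. The ring that enters keeps the size of the ring that leaves while adding a second hetero atom, and the core of compound 3 with its methyl-bearing phenoxy part stays in place. A step from compound 3 to compound 4 of modest size, leaning toward a somewhat higher number but possibly within the scatter, is expected: a 1.8-fold higher number from compound 3 to compound 4 (0.26 log units; within the scatter). For compound 4 in this assay the estimate is 250 nM, with a range from 80 nM to 800 nM.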

Compound 4, half-maximal effective concentration: 1100 nM
Beside the measured number, compound 4's estimate is 4.4-fold (0.64 log units) below it; the whole stated range lies below it.
By their numbers in this assay, from the lowest: compound 3; then compound 1; then compounds 2 and 4 (each within the scatter of the next).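

Among these compounds, the exchange of furan-3-yl for 1,3-thiazol-5-yl on a saturated chain carbon bound to an amide-type nitrogen gives the only single-place step available in this assay and amounts to an 8.1-fold higher number from compound 3 to compound 4 (0.91 log units; beyond the scatter) with the rest of the molecule unchanged. This position is therefore not indifferent to which five-membered aromatic ring it carries: two rings with the same heavy-atom count, both without hydrogen-bond donors and without net charge, stand clearly apart, and the ring with the second hetero atom needs larger amounts of compound for an effect. No measured property of either ring is available to explain the size of this step, so it stands as an observation without a stated cause.

The compounds shown leave open which change within the ring goes with the higher number, the loss of the oxygen or the arrival of the nitrogen and the sulfur. As far as these compounds go, a thiophen-3-yl or a 1,3-oxazol-5-yl group on the same chain carbon would help separate these changes, and whether the step holds with another group on the phenoxy part also remains open.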